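This account rests on a few compounds, and the source may have more. Where it says the series, first, only, none or still open, it means among the compounds named here.

Of the compounds shown here, two have been measured in a functional assay on OVCAR-4 cells (Homo sapiens) for antiproliferative activity, read by sulforhodamine B assay, with a stated time of 48 h; on this read-out lower numbers stand for stronger inhibition of growth and higher numbers for weaker inhibition of growth. Compound 1 `Nc1nn(C(=O)Nc2ccc(Cc3ccccc3)cc2)c2ccccc12` gives 40400 nM in this assay. Compound 2 `Nc1nn(C(=O)Nc2ccc(Cc3ccccc3)cc2)c2ccc(Cl)cc12`, which carries a chloro in place of hydrogen on an aromatic carbon, gives 34300 nM in this assay. Among the measured compounds shown here, the step of a 1.2-fold lower number from compound 1 to compound 2 (0.07 log units; within the scatter) lies within the scatter, so on the numbers so far compound 2 stands side by side with compound 1, neither separated from the other by more than repeated measurement would give.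

Compound 3 `Nc1ccc2c(c1)c(N)nn2C(=O)Nc1ccc(Cc2ccccc2)cc1` has not yet been measured in this assay. It differs from compound 2 by amino in place of chloro on an aromatic carbon. For the measured compounds named here, only one measured step bears on this change: a 1.2-fold lower number from compound 1 to compound 2 (0.07 log units; within the scatter) shows that exchanging the hydrogen at this aromatic carbon for a chloro left the number within the scatter. No measured step exchanges a chloro for an amino, so nothing is known about that exchange beyond what this one position has shown. The expectation for compound 3 is therefore a step within the scatter, a 1.1-fold higher number from compound 2 to compound 3 (0.04 log units; within the scatter). Compound 3 is estimated at 38000 nM in this assay, with a range from 12000 nM to 120000 nM.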

Compound 3, concentration for total growth inhibition: 24100 nM
Compound 3: middle estimate off by 1.6-fold (0.20 log units), on the high side; low and high end bracket the measured number.
By their numbers in this assay, from the lowest: compounds 3, 2 and 1 (each within the scatter of the next).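

In this assay this position, on an aromatic carbon meta to a fused ring and para to a fused ring, has now carried a second group. The exchange of chloro for amino, which brings in a hydrogen-bond donor and a hydrogen-bond acceptor where chloro counted neither, gives a 1.4-fold lower number from compound 2 to compound 3 (0.15 log units; within the scatter), and amino in place of hydrogen gives a 1.7-fold lower number from compound 1 to compound 3 (0.22 log units; within the scatter), so hydrogen, chloro and amino at this one carbon are not separated from one another by more than repeated measurement would give. No measurement is at hand that would explain these numbers, so the account stops at what they show.

What the compounds shown leave open is whether a larger group at this carbon, such as a carboxylic acid, an acetamide or a longer chain, would also stay within the scatter or would move the number beyond it. They also leave open whether the same holds at the other carbons of this ring, since every change shown falls at this one place and the rest of the shared core stays the same throughout.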